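From 2-bromophenyl to 4-hydroxyphenyl in a level series

The source may report more compounds than this note shows. Statements on the series, on what has been measured and on what is new or still open speak of the compounds shown alone.

Compound 1 `C[C@H]1CC[C@@H]2[C@@H](OC(=O)[C@]23CC(c2c(Cl)cccc2Cl)=NO3)[C@]2(C)C(=O)C=C[C@@]12O` gives 56000 nM 
Compound 2 `C[C@H]1CC[C@@H]2[C@@H](OC(=O)[C@]23CC(c2ccc(Cl)cc2)=NO3)[C@]2(C)C(=O)C=C[C@@]12O` gives 49000 nM 
Compound 3 `C[C@H]1CC[C@@H]2[C@@H](OC(=O)[C@]23CC(c2ccccc2Br)=NO3)[C@]2(C)C(=O)C=C[C@@]12O` gives 51000 nM 

These three values come from a functional assay on PC-3 cells (Homo sapiens) for cytotoxicity, read by sulforhodamine B assay, with a stated time of 48 h (on this read-out lower numbers stand for stronger inhibition and higher numbers for weaker inhibition), and sit close together. Compound 3 stands level with the other two: its steps to both lie within the scatter. Compound 4 `C[C@H]1CC[C@@H]2[C@@H](OC(=O)[C@]23CC(c2ccc(O)cc2)=NO3)[C@]2(C)C(=O)C=C[C@@]12O` has not been measured yet. It differs from compound 3 at one place, with 4-hydroxyphenyl in place of 2-bromophenyl on a carbon with a double bond to nitrogen. The measured swaps at this same place gave a 1.1-fold lower number from compound 1 to compound 3 (0.04 log units; within the scatter) and then a 1.0-fold higher number from compound 2 to compound 3 (0.02 log units; within the scatter) and also a 1.1-fold lower number from compound 1 to compound 2 (0.06 log units; within the scatter) and each of these lies within the scatter. Among the compounds with values here, none of the measured compounds carries 4-hydroxyphenyl, so these small steps are only a loose guide. Resting on them, the expected move in this assay is a 1.1-fold lower number from compound 3 to compound 4 (0.05 log units; within the scatter) and no step beyond the scatter is expected in either direction. For compound 4 the estimated value is 45000 nM with 20000 nM and 90000 nM as the expected ends of its range.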

Compound 4, half-maximal inhibitory concentration: 20000 nM
Estimate against measurement, compound 4: 2.3-fold (0.35 log units) above; the measured number falls inside the stated range.
By their numbers in this assay, from the lowest: compound 4; then compounds 2, 3 and 1 (each within the scatter of the next).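

Swapping one halogen-bearing phenyl group for another on this carbon had moved nothing beyond the scatter in this assay, so the position could have seemed indifferent to what it carries. The 4-hydroxyphenyl group changes that, with a 2.6-fold lower number from compound 3 to compound 4 (0.41 log units; beyond the scatter) and a 2.8-fold lower number from compound 1 to compound 4 (0.45 log units; beyond the scatter) as well as a 2.5-fold lower number from compound 2 to compound 4 (0.39 log units; beyond the scatter) as modest steps beyond the scatter, the last being only hydroxy in place of chloro on an aromatic carbon. The series therefore does respond to the group here, though nothing available explains why this group stands apart.

From the compounds shown here alone, what stays open is whether the hydroxy group itself matters or any similar group would serve. A methoxy group, an amine or a carboxylic acid on the phenyl ring would help to separate these possibilities.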